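Aryl tail variation on the shared core, agonist series

This account rests on a few compounds, and the source may have more. Where it says the series, first, only, none or still open, it means among the compounds named here.

Measured so far:
compound 1 `O=c1[nH]/c(=N\OCCOc2ccccc2)ccn1[C@@H]1O[C@H](COP(=O)(O)OP(=O)(O)OP(=O)(O)O)[C@@H](O)[C@H]1O`: 3400 nM
compound 2 `O=c1[nH]/c(=N\OCCCc2cccc(F)c2)ccn1[C@@H]1O[C@H](COP(=O)(O)OP(=O)(O)OP(=O)(O)O)[C@@H](O)[C@H]1O`: 190 nM
compound 3 `O=c1[nH]/c(=N\OCCCc2ccc(Br)cc2)ccn1[C@@H]1O[C@H](COP(=O)(O)OP(=O)(O)OP(=O)(O)O)[C@@H](O)[C@H]1O`: 350 nM

In a functional assay on 1321-N1 cells for agonist activity at P2Y purinoceptor 2 (Homo sapiens), read by scintillation counting and inositol phosphate accumulation (on this read-out lower numbers stand for an effect already at smaller amounts and higher numbers for an effect only at larger amounts of compound), compound 3 holds the second highest of the three numbers; its nearest neighbour is compound 2, within the scatter, while compound 1 lies well apart, as a 9.7-fold lower number from compound 1 to compound 3 (0.99 log units; beyond the scatter) shows. Compound 4 `O=c1[nH]/c(=N\OCCCc2cccc([N+](=O)[O-])c2)ccn1[C@@H]1O[C@H](COP(=O)(O)OP(=O)(O)OP(=O)(O)O)[C@@H](O)[C@H]1O` differs from compound 3 by 3-nitrophenyl in place of 4-bromophenyl on a saturated chain carbon, three bonds along the chain from an oxygen. Among the measured compounds shown here, the only measured step at this place is a 1.8-fold higher number from compound 2 to compound 3 (0.27 log units; within the scatter), which stays within the scatter; an 18-fold lower number from compound 1 to compound 2 (1.25 log units; beyond the scatter) concerns a different change and does not bear directly on the ring substituent. No step beyond the scatter is therefore expected for the ring substituent itself, a 1.2-fold lower number from compound 3 to compound 4 (0.07 log units; within the scatter). Compound 4 is estimated at 300 nM, expected between 100 nM and 900 nM.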

Compound 4, half-maximal effective concentration: 457 nM
The estimate for compound 4 lay 1.5-fold (0.18 log units) below the measured number, and the stated range covers the measured number.
By their numbers in this assay, from the lowest: compounds 2, 3 and 4 (each within the scatter of the next, the first and the last beyond it); then compound 1.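

In this assay, 3-nitrophenyl in place of 4-bromophenyl gives a 1.3-fold higher number from compound 3 to compound 4 (0.12 log units; within the scatter), so this change of both substituent and ring place leaves no readable difference. Nitro in place of fluoro on an aromatic carbon gives a 2.4-fold higher number from compound 2 to compound 4 (0.38 log units; beyond the scatter), the only ring step shown beyond the scatter, though modest, while 3-nitrobenzyl in place of phenoxy still gives a 7.4-fold lower number from compound 1 to compound 4 (0.87 log units; beyond the scatter). No evidence here accounts for these steps. As far as these compounds go, whether an amine or a carboxylic acid on that aromatic carbon would keep the number in this range remains open, as does the effect of a longer chain.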